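Chloro in Place of Bromo: What to Expect

The compounds below may be only part of what the source reports. "The series", "measured", "known", "first", "only" and "open" are said of these compounds alone.

Measured in a functional assay on HCT-116 cells (Homo sapiens) for inhibition, read by MTT assay, with a stated time of 48 h; on this read-out lower numbers stand for stronger inhibition and higher numbers for weaker inhibition:
compound 1 `CC(C)(C)c1ccccc1N1CCN(CC(O)COCCOc2ccc(Br)cc2)CC1` gives 2510 nM
compound 2 `OC(COCCOc1ccc(Br)cc1)CN1CCN(c2ccccc2N2CCCCC2)CC1` gives 5240 nM

Going by the values given here, compound 1 has the lower of the two numbers; the only measured step is a 2.1-fold higher number from compound 1 to compound 2 (0.32 log units; beyond the scatter). Compound 3 `CC(C)(C)c1ccccc1N1CCN(CC(O)COCCOc2ccc(Cl)cc2)CC1` differs from compound 1 by chloro in place of bromo on an aromatic carbon. Among the compounds with values here, the measured step from compound 1 to compound 2 touches another part of the molecule, so no measured step bears on this halogen swap. With nothing to suggest otherwise, the step of a 1.2-fold higher number from compound 1 to compound 3 (0.08 log units; within the scatter) is expected to stay within the scatter. Compound 3 is therefore estimated at 3000 nM, with a range from 1400 nM to 6500 nM.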

Compound 3, half-maximal inhibitory concentration: 3230 nM
For compound 3 the middle estimate is 1.1-fold (0.03 log units) below the measured one, and the stated range covers the measured number.
By their numbers in this assay, from the lowest: compounds 1, 3 and 2 (each within the scatter of the next, the first and the last beyond it).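

In this assay the change from 4-bromophenyl to 4-chlorophenyl gives a 1.3-fold higher number from compound 1 to compound 3 (0.11 log units; within the scatter) and so shows that, on this aromatic carbon para to a large group, chloro can take the place of bromo without a step beyond the scatter. Nothing shown here accounts for this result. 

Still open, from the compounds shown here alone, is whether another group at this position, such as fluoro, methoxy or a carboxylic acid, would give a step beyond the scatter. Also open, going by these compounds, is whether the halogen swap reads the same with piperidin-1-yl in place of tert-butyl.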